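This account rests on a few compounds, and the source may have more. Where it says the series, first, only, none or still open, it means among the compounds named here.

Three compounds have been measured in a functional assay on MCF7 cells (Homo sapiens) for antiproliferative activity, read by MTT assay, with a stated time of 48 h; a lower number here means a stronger inhibitor, a higher number a weaker inhibitor:

- compound 1 `COc1ccc(C(=O)c2ccc3c(c2)C=CC(C)(C)O3)c(NC(=O)CBr)c1`: 2880 nM
- compound 2 `COc1ccc(C(=O)c2ccc(OC)c3c2OC(C)(C)C=C3)c(NC(=O)CO)c1`: 320 nM
- compound 3 `COc1ccc(C(=O)c2ccc3c(c2)C=CC(C)(C)O3)c(NC(=O)CN)c1`: 680 nM

Compound 3 stands in the middle of these numbers, with compound 2 lower at 320 nM and compound 1 higher at 2880 nM. The next compound, compound 4 `CCNCC(=O)Nc1cc(OC)ccc1C(=O)c1ccc2c(c1)C=CC(C)(C)O2`, differs from compound 3 by ethyl in place of hydrogen on an amine nitrogen.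

Among the measured compounds shown here, only one measured step bears on this change: a 4.2-fold lower number from compound 1 to compound 3 (0.63 log units; beyond the scatter). It is modest and beyond the scatter, and it replaces bromo with amino on a saturated chain carbon bound to a carbonyl carbon. It therefore touches the same side chain but is a different exchange. For the measured compounds named here, no measured pair shows what a substituent on the amine nitrogen does, so the data set no direction, and no step beyond the scatter is expected in this assay. The estimated step is a 1.1-fold lower number from compound 3 to compound 4 (0.05 log units; within the scatter), and the wide expected range reflects this thin evidence. Compound 4 is estimated at 600 nM, with an expected range of 220 nM to 1700 nM.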

Compound 4, half-maximal inhibitory concentration: 6310 nM
Beside the measured number, compound 4's estimate is 11-fold (1.02 log units) below it, and the stated range ends below it.
By their numbers in this assay, from the lowest: compound 2; then compound 3; then compound 1; then compound 4.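

In this assay, among the compounds shown here, the amine nitrogen of the side chain proves sensitive to substitution: ethyl in place of hydrogen gives a 9.3-fold higher number from compound 3 to compound 4 (0.97 log units; beyond the scatter) and is the first measured change at this nitrogen. The gain seen with amino over bromo does not carry over to ethylamino, which gives a 2.2-fold higher number from compound 1 to compound 4 (0.34 log units; beyond the scatter) and so ends on the weaker side of the bromo compound. No measurement given here accounts for this loss.

Going by these compounds, whether a single methyl on the nitrogen already costs as much as ethyl, and whether dimethylamino or a longer chain goes further, remains open. Compound 2 differs from the others in more than one place, so steps to it cannot be read, and the effect of hydroxy against amino on this chain stays unresolved.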